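Compound 1 to compound 3: adding a trifluoromethyl group

The source may hold more compounds than are shown below. What is called first, only, known or untested is meant among the compounds shown, and "the series" means these compounds.

For the measured compounds named here, in a functional assay on MIA PaCa-2 cells (Homo sapiens) for cytotoxicity, read by MTT assay, with a stated time of 72 h (a lower number here means a stronger inhibitor, a higher number a weaker inhibitor), compound 1 (`COC1=CC(=O)c2c(COc3ccccc3)c(C)n(C)c2C1=O`) gives 409 nM as the higher of the two numbers so far. Compound 2 (`COC1=CC(=O)c2c(COc3ccccc3[N+](=O)[O-])c(C)n(C)c2C1=O`) stands lower at 178 nM in the same measurement. Compound 3 (`COC1=CC(=O)c2c(COc3ccc(C(F)(F)F)cc3)c(C)n(C)c2C1=O`) awaits measurement. It differs from compound 1 by trifluoromethyl in place of hydrogen on an aromatic carbon, para to a large group (trifluoromethyl in place of hydrogen on an aromatic carbon). Going by the values given here, one measured step bears on this: nitro in place of hydrogen on an aromatic carbon gave a 2.3-fold lower number from compound 1 to compound 2 (0.36 log units; beyond the scatter) as a modest change. On this single precedent, a similarly modest step toward a lower number is expected in this assay here. The expected step is a 1.6-fold lower number from compound 1 to compound 3 (0.21 log units; within the scatter) in size. Compound 3 is estimated at 250 nM (expected range 100 nM to 600 nM).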

Compound 3, half-maximal inhibitory concentration: 311 nM
For compound 3 the middle estimate is 1.2-fold (0.09 log units) below the measured one, within the range that was stated.
By their numbers in this assay, from the lowest: compounds 2, 3 and 1 (each within the scatter of the next, the first and the last beyond it).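

In this assay, trifluoromethyl in place of hydrogen on an aromatic carbon, para to a large group, gives a 1.3-fold lower number from compound 1 to compound 3 (0.12 log units; within the scatter) and so stays within the scatter, unlike the nitro change, which gave a 2.3-fold lower number from compound 1 to compound 2 (0.36 log units; beyond the scatter) at a different ring carbon. A substituent on this ring therefore does not always produce a step beyond the scatter. No available evidence bears on the reason for either step.

Still open, as far as these compounds go, is whether an amine or a carboxylic acid at this place gives a step beyond the scatter. Also open, from the compounds shown here alone, is how trifluoromethyl and nitro compare on the same ring carbon.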